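Methoxy for Methyl on a Benzylamide Pyranone Core

A few compounds are considered here, and "the series" means these few. Any claim that something is new, unique, unknown or untested is made for them only; others in the source may bear on it.

Compound 1 `Cc1ccc(NC(=O)c2c(NO)cc(-c3ccc(C)cc3)oc2=O)cc1` was examined in an ADME assay on Huh-7 cells (Homo sapiens) for cytotoxicity, read by a luciferase reporter and WST assay, with a stated time of 3 days; a higher number here means that more compound is tolerated, a lower number that less compound is tolerated. Compound 1 gives > 20000 nM, which is a limit of the assay and not a number. Compound 2 `COc1ccc(-c2cc(NO)c(C(=O)Nc3ccc(C)cc3)c(=O)o2)cc1` differs from compound 1 by methoxy in place of methyl on an aromatic carbon. In this assay compound 2 gives > 20000 nM, again a limit. Compound 3 `Cc1ccc(-c2cc(NO)c(C(=O)NCc3ccccc3)c(=O)o2)cc1` carries a different amide substituent; the two cores differ by benzyl in place of 4-methylphenyl on an amide-type nitrogen. In this assay compound 3 gives > 20000 nM, also a limit. The step that the two limits leave unreadable from compound 1 to compound 2 and the step that the two limits leave unreadable from compound 1 to compound 3 thus cannot be sized, because every value sits at the limit of > 20000 nM in this assay, at which 3 of the 3 values shown sit.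

Compound 4 `COc1ccc(-c2cc(NO)c(C(=O)NCc3ccccc3)c(=O)o2)cc1` is not yet measured. It differs from compound 3 by methoxy in place of methyl on an aromatic carbon, the same change as that from compound 1 to compound 2, at the same place. In this assay the step from compound 3 to compound 4 is expected to be a step that the limit leaves unreadable from compound 3 to compound 4, which rests on the unreadable step that the two limits leave unreadable from compound 1 to compound 2 and on (the limit of > 20000 nM in this assay, at which 3 of the 3 values shown sit). Compound 4 is estimated to give 25000 nM in this assay, with an expected range from 12000 nM to 60000 nM.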

Compound 4, half-maximal cytotoxic concentration: > 20000 nM
Compound 4: no number, only a limit; the forecaster's own chance of this, stated with the estimate: 85%; the middle value does not contradict the limit.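

In this assay compound 4 gives > 20000 nM, which is a limit of the assay and not a number. The steps to compound 4 from compound 3 and from compound 2 cannot be read, because all the values stand at the same limit: the limit of > 20000 nM in this assay, at which 4 of the 4 values shown sit. The compounds shown leave open whether either change, methoxy for methyl or benzyl for 4-methylphenyl, alters the concentration tolerated at all.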